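This account rests on a few compounds, and the source may have more. Where it says the series, first, only, none or still open, it means among the compounds named here.

Measured in a functional assay on K562 cells (Homo sapiens) for cytotoxicity, read by MTT assay, with a stated time of 48 h; on this read-out lower numbers stand for stronger inhibition and higher numbers for weaker inhibition:
- compound 1 `Cc1cccc(CN2CCN(C(=O)CN[C@H]3CCN(S(=O)(=O)Cc4ccccc4)C3)CC2)c1`: 11300 nM
- compound 2 `Cc1cc(C)c(CN2CCN(C(=O)CN[C@H]3CCN(S(=O)(=O)Cc4ccccc4)C3)CC2)c(C)c1`: 3300 nM
- compound 3 `O=C(CN[C@H]1CCN(S(=O)(=O)Cc2ccccc2)C1)N1CCN(Cc2ccc(Cl)cc2Cl)CC1`: 4300 nM

Compound 3 lies within the scatter of compound 2, and a 2.6-fold lower number from compound 1 to compound 3 (0.42 log units; beyond the scatter) separates it from compound 1. Compound 4 `O=C(CN[C@H]1CCN(S(=O)(=O)Cc2ccccc2)C1)N1CCN(Cc2c(Cl)cccc2Cl)CC1` carries 2,6-dichlorophenyl in place of 2,4-dichlorophenyl on a saturated chain carbon bound to an amine nitrogen in a ring. Among the measured compounds shown here, no measured step moves a chlorine, so the evidence is indirect. Replacing 3-methylphenyl gave a 3.4-fold lower number from compound 1 to compound 2 (0.53 log units; beyond the scatter), and exchanging the two more substituted rings gave only a 1.3-fold higher number from compound 2 to compound 3 (0.11 log units; within the scatter). In this assay, no step beyond the scatter is therefore expected, and the estimated step is a 1.0-fold lower number from compound 3 to compound 4 (0.01 log units; within the scatter). For compound 4 the expected value is 4200 nM, with an estimated range of 1800 nM to 10000 nM.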

Compound 4, half-maximal inhibitory concentration: 28400 nM
Compound 4: the middle estimate sits 6.8-fold (0.83 log units) below what was measured; measured number above the stated range.
By their numbers in this assay, from the lowest: compounds 2 and 3 (each within the scatter of the next); then compound 1; then compound 4.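

In this assay, the same atoms joined differently are not equivalent at this position: 2,6-dichlorophenyl in place of 2,4-dichlorophenyl gives a 6.6-fold higher number from compound 3 to compound 4 (0.82 log units; beyond the scatter). The 2,6-dichlorophenyl ring also trails the 2,4,6-trimethylphenyl ring, with an 8.6-fold higher number from compound 2 to compound 4 (0.93 log units; beyond the scatter), and the 3-methylphenyl ring, with a 2.5-fold higher number from compound 1 to compound 4 (0.40 log units; beyond the scatter), making compound 4 the weakest of the four. No measurement shown here accounts for this loss.

From the compounds shown here alone, it remains open whether a 2,6-dimethylphenyl ring would track compound 2 or compound 4, which would separate the substitution pattern from the identity of the substituent.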